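Replacing 6-(hydroxymethyl)pyridin-3-yl with 4-cyanophenyl

The source may hold more compounds than are shown below. What is called first, only, known or untested is meant among the compounds shown, and "the series" means these compounds.

In an in vitro ADME assay on microsomes from liver (Homo sapiens) for metabolic stability, with a stated time of 60 min, tested at 1 uM (on this read-out higher numbers stand for fast clearance and lower numbers for slow clearance), compound 2 `CS(=O)(=O)c1ccc(-c2cnc(N)c(-c3ccc(CO)nc3)c2)cc1` gives < 7 mL.min-1.g-1, which is a limit of the assay and not a number. Compound 1 `Cc1ccc(-c2cc(-c3ccc(S(C)(=O)=O)cc3)cnc2N)cn1` gives < 5 mL.min-1.g-1, which is also a limit. That leaves a step that the two limits leave unreadable from compound 1 to compound 2, so no size can be carried forward from it. Compound 3 `Cc1ccc(-c2cc(-c3ccc(S(C)(=O)=O)cc3)cnc2N)cc1C(F)(F)F` does give a number, 23 mL.min-1.g-1. The change to compound 4 `CS(=O)(=O)c1ccc(-c2cnc(N)c(-c3ccc(C#N)cc3)c2)cc1` is 4-cyanophenyl in place of 6-(hydroxymethyl)pyridin-3-yl on an aromatic carbon. No measured step sizes this change directly, so the expectation leans on compound 3 at 23 mL.min-1.g-1, which also has an aromatic ring of carbon only at that place. The expected step, towards faster clearance, is an at least 1.5-fold higher number from compound 2 to compound 4 (0.19 log units; that floor lies within the scatter). For compound 4 the estimated clearance is 11 mL.min-1.g-1, within an expected range of 4 mL.min-1.g-1 to 28 mL.min-1.g-1.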

Compound 4, intrinsic clearance in microsomes: < 5 mL.min-1.g-1
Compound 4: only a limit was reported; the forecaster's own chance of this, stated with the estimate: 30%; at least 2.2-fold (0.34 log units) between middle value and limit.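

Compound 4 gives only a limit, as do compound 1 and compound 2, so no step among these three can be read. The compounds shown leave open whether 4-cyanophenyl in place of 6-(hydroxymethyl)pyridin-3-yl changes clearance at all.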